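Hydrated triketone cores: a ring substituent added to compound 2

The source may hold more compounds than are shown below. What is called first, only, known or untested is meant among the compounds shown, and "the series" means these compounds.

Compound 1 `O=C1c2cccc(O)c2C(=O)C1(O)O` gives, in an assay on isolated protein for inhibition of carbonic anhydrase 4 (Homo sapiens), read by stopped-flow, with a stated time of 15 min (a higher number here means a weaker inhibitor, a lower number a stronger inhibitor), the limit > 100000 nM.
Compound 2 `COc1cccc2c1C(=O)C(O)(O)C2=O` gives in this assay the limit > 100000 nM.

Both results are limits of the assay, not numbers. Compound 2 thus stands at the limit of > 100000 nM in this assay, at which 2 of the 2 values shown sit. The step from compound 1 to compound 2 is a step that the two limits leave unreadable from compound 1 to compound 2, so its size cannot be read. Compound 3 `COc1ccc(CNC(=O)CCl)c2c1C(=O)C(O)(O)C2=O` has not yet been measured; it differs from compound 2 by (((chloromethyl)carbonyl)amino)methyl in place of hydrogen on an aromatic carbon. No measured step bears on this change, and the only step shown is itself unreadable, so there is no basis to expect a move in either direction beyond the scatter. Compound 3 is therefore expected to sit near the limit as well, with the step of a number no higher from compound 2 to compound 3 (the limit leaves the size open) an estimate only. For compound 3 the expected inhibition constant in this assay is 100000 nM, within a range of 20000 nM to 500000 nM.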

Compound 3, inhibition constant: > 100000 nM
Compound 3: no number, only a limit; the forecaster's own chance of this, stated with the estimate: 70%; the middle value sits exactly at the limit.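

Among these compounds, compound 2 and compound 3 both give limits of the assay, not numbers, and no step between them can be read: the limit of > 100000 nM in this assay, at which 3 of the 3 values shown sit. The compounds shown leave open whether any change on the shared core gives a readable inhibition constant in this assay.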